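Replacing a Ring Amide Partner with a Hydroxy Group

The source may report more compounds than this note shows. Statements on the series, on what has been measured and on what is new or still open speak of the compounds shown alone.

Compound 2 `O=C(NC[C@@H]1CCCc2cc(S(=O)(=O)c3cccc(F)c3)ccc21)[C@H]1CCCN1` is the stronger of the two measured compounds in an assay on isolated protein for displacement of a labelled ligand from 5-hydroxytryptamine receptor 6 (Homo sapiens); on this read-out higher numbers stand for weaker inhibition and lower numbers for stronger inhibition. In this assay compound 2 gives 0.631 nM, while compound 1 `NC[C@@H]1CCCc2cc(S(=O)(=O)Cc3ccccc3)ccc21`, which carries a free aminomethyl group on the shared core and a different sulfonyl substituent, gives 158 nM; the gap between these two values lies far beyond the usual scatter. Compound 3 `CC(C)(O)C(=O)NC[C@@H]1CCCc2cc(S(=O)(=O)c3cccc(F)c3)ccc21` has not yet been measured. It differs from compound 2 in one place: 1-hydroxy-1-methylethyl in place of pyrrolidin-2-yl on a carbonyl carbon. For the measured compounds named here, no measured pair shows the effect of this kind of exchange, so the direction of the step has to be judged without a direct precedent. The expectation is that compound 3 loses some binding relative to compound 2, with the step from compound 2 to compound 3 expected to be a 9.5-fold higher number from compound 2 to compound 3 (0.98 log units; beyond the scatter). Compound 3 is therefore estimated at 6 nM in this assay, within a range from 1.5 nM to 30 nM.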

Compound 3, inhibition constant: 2 nM
Compound 3: middle estimate off by 3.0-fold (0.48 log units), on the high side; measured number inside the range.
By their numbers in this assay, from the lowest: compound 2; then compound 3; then compound 1.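

In this assay the exchange of pyrrolidin-2-yl for 1-hydroxy-1-methylethyl on a carbonyl carbon gives a 3.2-fold higher number from compound 2 to compound 3 (0.50 log units; beyond the scatter) and so costs only a modest amount of binding. This shows that the position tolerates losing the five-membered ring, its defined stereocentre and its nitrogen: compound 3 , with no ring in this group, still gives 2 nM in this comparison. No measurement is available to explain why the step has this size.

On these data alone, it remains open whether the hydroxy group of 1-hydroxy-1-methylethyl contributes to this value, which a matching compound carrying a plain tert-butyl group on the same carbonyl carbon could show. As far as these compounds go, it is also open how an open-chain amine such as 1-amino-1-methylethyl would compare with the two groups seen here.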